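Shortening the amine chain on the core of compound 1

This account rests on a few compounds, and the source may have more. Where it says the series, first, only, none or still open, it means among the compounds named here.

Compound 1 `CNCCCNc1c(F)cc2c(=O)c(C(=O)O)cn(Cc3ccc(-c4ccccc4)cc3)c2c1OC` was tested in an assay on isolated protein for inhibition of DNA topoisomerase 1 (Homo sapiens), with a stated time of 15 min (a lower number here means a stronger inhibitor, a higher number a weaker inhibitor), where compound 1 gives 101000 nM. Of the two numbers measured in that assay, this is the highest. Its nearest neighbour is compound 3 `NC[C@@H]1CCN(c2cc3c(cc2F)c(=O)c(C(=O)O)cn3Cc2ccc(-c3ccc(F)cc3)cc2)C1`, and in this assay compound 3 gives 69600 nM, a value that sits within the usual scatter of the value of compound 1, so no order between the two can be read. Compound 2 `COc1c(N2CC[C@@H](CN)C2)c(F)cc2c(=O)c(C(=O)O)cn(Cc3ccc(-n4cccn4)cc3)c12` in this assay returns only a limit of the assay, > 200000 nM, and no number. This is the limit of > 200000 nM in this assay, at which 1 of the 3 values shown sits.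

Compound 4 `CNCCNc1c(F)cc2c(=O)c(C(=O)O)cn(Cc3ccc(-c4ccccc4)cc3)c2c1OC` has not yet been measured. It differs from compound 1 in one place: methylamino in place of (methylamino)methyl on a saturated chain carbon, two bonds along the chain from a nitrogen on an aromatic ring. For the measured compounds named here, no pair of measured compounds differs in this way, so the size of the step is not known from the data. The author expects a step from compound 1 to compound 4 of a 1.0-fold lower number from compound 1 to compound 4 (0.00 log units; within the scatter), that is, nothing beyond the scatter in either direction. Compound 4 is therefore estimated at 100000 nM, with a range from 40000 nM to 250000 nM.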

Compound 4, half-maximal inhibitory concentration: > 200000 nM
Compound 4: no number, only a limit; the forecaster's own chance of this, stated with the estimate: 25%; at least 2.0-fold (0.30 log units) between middle value and limit.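

In this assay compound 4 returns only a limit of the assay, > 200000 nM, and no number. The change on this saturated chain carbon, from (3-(methylamino)propyl)amino to (2-(methylamino)ethyl)amino, is the first one-place step among these compounds, and it reads an at least 1.9-fold higher number from compound 1 to compound 4 (0.29 log units; that floor lies within the scatter); it therefore has only a floor, so it cannot be said how far the shorter chain moves the result or whether it moves it beyond the scatter. Compound 4 is the second compound shown at that limit: the limit of > 200000 nM in this assay, at which 2 of the 4 values shown sit.

The compounds shown do not tell what a longer chain ending in methylamino would give at this position. They also leave open whether a primary amine or a dimethylamino group at the chain end would give a measurable number on this core.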